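The source may report more compounds than this note shows. Statements on the series, on what has been measured and on what is new or still open speak of the compounds shown alone.

The series shares one core, carried by compound 1 `COc1ccc2c(=O)c(/C=C/C(=O)Nc3cc(C)ccc3C)coc2c1`, compound 2 `COc1ccc2c(=O)c(/C=C/C(=O)NCc3ccc(C)cc3)coc2c1` and compound 3 `COc1ccc(NC(=O)/C=C/c2coc3cc(OC)ccc3c2=O)cc1`. In an ADME assay on HepG2 2.2.15 cells (Homo sapiens) for cytotoxicity, read by MTT assay, with stated times of 48 h and 9 days (a lower number here means that less compound is tolerated, a higher number that more compound is tolerated), compound 1 gives 1100000 nM, compound 2 gives 257000 nM and compound 3 gives 718000 nM. Compound 3 therefore stands second highest of the three numbers, within the scatter of compound 1 and separated from compound 2 by a step beyond it, a 2.8-fold higher number from compound 2 to compound 3 (0.45 log units; beyond the scatter). Compound 4 `COc1ccc2c(=O)c(/C=C/C(=O)Nc3cccc(C)c3)coc2c1` differs from compound 3 in one place: 3-methylphenyl in place of 4-methoxyphenyl on an amide-type nitrogen. Among the compounds with values here, no measured step exchanges a methoxy for a methyl on a phenyl carried by the amide-type nitrogen, so the bearing is indirect. The step of a 1.5-fold lower number from compound 1 to compound 3 (0.19 log units; within the scatter) shows that exchanging one substituted phenyl for another moved the number only within the scatter, while a 4.3-fold lower number from compound 1 to compound 2 (0.63 log units; beyond the scatter) shows that the larger shift came with a benzyl group. Since compound 4 keeps a substituted phenyl directly on the nitrogen, the expected step of a 1.1-fold higher number from compound 3 to compound 4 (0.05 log units; within the scatter) is small, within the scatter, with no direction favoured. Compound 4 is thus estimated at 800000 nM, ranging from 350000 nM to 1800000 nM in this assay.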

Compound 4, half-maximal cytotoxic concentration: 554000 nM
Beside the measured number, compound 4's estimate is 1.4-fold (0.16 log units) above it; measured number inside the range.
By their numbers in this assay, from the lowest: compound 2; then compounds 4, 3 and 1 (each within the scatter of the next).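

In this assay, a phenyl with a methyl and no oxygen sits within the scatter of the methoxy-bearing phenyl on the amide-type nitrogen (a 1.3-fold lower number from compound 3 to compound 4 (0.11 log units; within the scatter)), and hydrogen in place of methyl on an aromatic carbon also stays within it (a 2.0-fold lower number from compound 1 to compound 4 (0.30 log units; within the scatter)). Compound 2 stays apart from compound 4 as well (a 2.2-fold higher number from compound 2 to compound 4 (0.33 log units; beyond the scatter)), so all three compounds with a phenyl directly on the nitrogen now lie beyond the scatter of the 4-methylbenzyl compound. No supporting data are available to explain these numbers.

The compounds shown leave open whether that gap follows from the benzyl link or from where the methyl sits. They also leave open how a phenyl bearing an amine or a carboxylic acid, or a longer chain on the nitrogen, would stand.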